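The compounds below may be only part of what the source reports. "The series", "measured", "known", "first", "only" and "open" are said of these compounds alone.

Compound 1, `CC(=O)Nc1c(C(O)(C(F)(F)F)C(F)(F)F)ccc2ccccc12`, gives 87% in a functional assay (Sus scrofa) with sulfonylurea receptors; K-ATP channels (Homo sapiens) as the target; on this read-out higher numbers stand for larger maximal responses and lower numbers for smaller maximal responses.
Compound 2, `O=C(Nc1c(C(O)(C(F)(F)F)C(F)(F)F)ccc2ccccc12)C1CC1`, gives 100% in this assay.
Compound 3, `O=C(Nc1c(C(O)(C(F)(F)F)C(F)(F)F)ccc2ccccc12)C1CCC1`, gives 97% in this assay.

Compound 2 holds the highest number of the three. Its nearest neighbour is compound 3, with a number 3 percentage points lower from compound 2 to compound 3 (within the scatter), a gap within the scatter; its furthest is compound 1, with a number 13 percentage points higher from compound 1 to compound 2 (beyond the scatter), a gap beyond the scatter. Compound 3 also sits apart from compound 1 by a number 10 percentage points higher from compound 1 to compound 3 (within the scatter), which stays within the scatter.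

Compound 4, `O=C(Nc1c(C(O)(C(F)(F)F)C(F)(F)F)ccc2ccccc12)c1cccc([N+](=O)[O-])c1`, is not yet measured. It differs from compound 2 by 3-nitrophenyl in place of cyclopropyl on a carbonyl carbon.

All three measured steps change the group on the same carbonyl carbon, so all of them bear on this step. Yet none of them exchanges a small ring for an aromatic ring carrying a nitro group; they only move between methyl, cyclopropyl and cyclobutyl, and the largest of them was modest. Compound 2 already stands at the top of the range, which leaves little room upward. The expectation for compound 4 is therefore a step of a number 10 percentage points lower from compound 2 to compound 4 (within the scatter), a small decrease or none beyond the scatter. Compound 4 is expected to give 90% in this assay, with a range from 70% to 105%.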

Compound 4, largest response reached (reported as efficacy), in percent of the reference or control that the assay uses: 99%
The estimate for compound 4 lay 9 percentage points below the measured number; low and high end bracket the measured number.
By their numbers in this assay, from the lowest: compounds 1, 3, 4 and 2 (each within the scatter of the next, the first and the last beyond it).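

At the carbonyl carbon of the shared core, a much larger group is accepted in this assay: replacing the small rings with 3-nitrophenyl, with its nine heavy atoms, six-membered aromatic ring and two hydrogen-bond acceptors, gives a number 1 percentage points lower from compound 2 to compound 4 (within the scatter) and a number 2 percentage points higher from compound 3 to compound 4 (within the scatter), so neither change moves the response beyond the scatter. Measured against the methyl group, the aromatic group gives a number 12 percentage points higher from compound 1 to compound 4 (beyond the scatter), which places it with cyclopropyl in separating from methyl, while cyclobutyl goes against any such pattern with a number 10 percentage points higher from compound 1 to compound 3 (within the scatter). No supporting measurement bears on the reason that so different a group gives a response matching those of the small rings.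

The compounds shown leave open what the nitro group itself contributes, which a plain phenyl or an aminophenyl group on the same carbonyl carbon would help to separate from the contribution of the aromatic ring. They also leave open whether a longer alkyl chain or a group carrying a carboxylic acid at this place would keep the response, and whether any change elsewhere on the shared core would alter it.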